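Removing a Methoxy Group from a Carbamate Inhibitor

The source may report more compounds than this note shows. Statements on the series, on what has been measured and on what is new or still open speak of the compounds shown alone.

Compound 2 `COc1ccc2c(ccn2CCC2CCN(C(=O)Oc3ccccc3)CC2)c1` carries a methoxy group on one of its aromatic rings; in an assay on microsomes from brain for inhibition of Fatty-acid amide hydrolase 1 (Rattus norvegicus), read by HPLC, with a stated time of 60 min (a higher number here means a weaker inhibitor, a lower number a stronger inhibitor), compound 2 gives 360 nM. This is the highest of the two numbers recorded so far; the nearest is compound 1 `O=C(Oc1ccccc1)N1CCC(CCn2ccc3ccc(F)cc32)CC1`, which in this assay gives 46 nM, a gap that lies beyond the usual scatter. Compound 3 `O=C(Oc1ccccc1)N1CCC(CCn2ccc3ccccc32)CC1` is the analogue without that substituent: hydrogen in place of methoxy on an aromatic carbon. Within the data shown here, no single-change step between two measured compounds is available here, so the effect of this change cannot be read directly; the two values only show that compound 2 stands above compound 1. The change is expected to lower the number by a moderate step of a 3.3-fold lower number from compound 2 to compound 3 (0.51 log units; beyond the scatter), bringing the compound part of the way toward compound 1. Compound 3 is therefore expected to give 110 nM in this assay, with a range from 40 nM to 300 nM.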

Compound 3, half-maximal inhibitory concentration: 110 nM
Compound 3: the middle estimate sits on the measured number at the digits printed, within the range that was stated.
By their numbers in this assay, from the lowest: compound 1; then compound 3; then compound 2.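

With compound 3 available, the methoxy group can be judged on its own: in this assay its replacement by hydrogen gives a 3.3-fold lower number from compound 2 to compound 3 (0.51 log units; beyond the scatter), so compound 3 is the stronger inhibitor of this pair. Compound 3 also provides a reference for the fluoro group, since putting hydrogen in place of fluoro on an aromatic carbon gives a 2.4-fold higher number from compound 1 to compound 3 (0.38 log units; beyond the scatter). Set against this one hydrogen compound, the two groups move the number in opposite directions, methoxy upward and fluoro downward, although each step concerns only its own group and place.

No measurement shown here explains why either change has this effect. On these data alone, whether a chloro group, a hydroxyl group or an amine on the same aromatic carbon would raise or lower the number remains open.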